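The source may hold more compounds than are shown below. What is called first, only, known or untested is meant among the compounds shown, and "the series" means these compounds.

Compound 1 `COc1ccc(N(CC(=O)NCCCSc2ccccc2)C(=O)CCSC2=C(C)C(=O)c3ccccc3C2=O)cc1`: 4.2
Compound 2 `COc1ccc(N(CC(=O)NCCCSc2ccccc2)C(=O)/C=C/c2ccccc2)cc1`: 4
Compound 3 `COc1ccc(N(CC(=O)NCCC[Se]c2ccccc2)C(=O)/C=C/c2ccccc2)cc1`: 3.7

In a physicochemical assay for lipophilicity, read by HPLC, measured as octanol-water partition (a lower number here means a more polar compound, a higher number a more lipophilic compound), compound 1 gives 4.2. The reading of compound 2 lies within the scatter of that of compound 1, while the reading of compound 3 lies beyond it. Compound 4 `COc1ccc(N(CC(=O)NCCC[Te]c2ccccc2)C(=O)CCSC2=C(C)C(=O)c3ccccc3C2=O)cc1` differs from compound 1 by a group of 7 heavy atoms (6 carbon, 1 tellurium; one six-membered aromatic ring of carbon only) in place of a group of 7 heavy atoms (6 carbon, 1 sulfur; one six-membered aromatic ring of carbon only), on a saturated chain carbon, three bonds along the chain from an amide-type nitrogen. Within the data shown here, the only measured step that bears on this exchange is a number 0.30 log units lower from compound 2 to compound 3 (within the scatter), where selenium took the place of sulfur at the same place on the chain. Among the measured compounds shown here, no measured step covers tellurium in place of sulfur. On the strength of the selenium step, a small change at most, if any, is expected in this assay. For compound 4 the expected step is a number 0.20 log units lower from compound 1 to compound 4 (within the scatter). Compound 4 is therefore estimated at 4, with a range from 3.5 to 4.5.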

Compound 4, partition coefficient: 1.97
Beside the measured number, compound 4's estimate is 2.03 log units above it; measured number outside the range, below it.
By their numbers in this assay, from the lowest: compound 4; then compounds 3, 2 and 1 (each within the scatter of the next, the first and the last beyond it).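

In this assay, the tellurium group in place of phenylsulfanyl gives a number 2.23 log units lower from compound 1 to compound 4 (beyond the scatter), so this place on the chain can carry a large step, whereas the selenium exchange gave only a number 0.30 log units lower from compound 2 to compound 3 (within the scatter). The identity of the atom in this group can therefore matter here, even though the heavy-atom count stays the same. Nothing available accounts for the size of the step.

As far as these compounds go, whether tellurium gives a similar step on the core of compound 2 stays open, since the two exchanges were read on different cores. Also open, from the compounds shown here alone, is how the reading responds to a methyl group on tellurium in place of the aromatic ring, or to a longer chain.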